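Swapping the furan for a pyridine with a pyrrolidine

This account rests on a few compounds, and the source may have more. Where it says the series, first, only, none or still open, it means among the compounds named here.

In an in vitro assay on HEK385-7 cells for displacement of a labelled ligand from prostaglandin D2 receptor 2 (Homo sapiens) (a lower number here means a stronger inhibitor, a higher number a weaker inhibitor), compound 1 `O=C(O)Cc1sc(C(c2ccccc2)c2ccccc2)nc1-c1ccc(C(F)(F)F)cc1` gives 1100 nM, compound 2 `O=C(O)Cc1sc(C(c2ccccc2)c2ccc(F)c(F)c2)nc1-c1ccc(F)cc1` gives 10 nM, and compound 3 `O=C(O)Cc1sc(C(c2ccc(F)cc2)c2ccc(F)cc2)nc1-c1ccco1` gives 18 nM. Compound 3 thus has the second highest of the three numbers: its value and that of compound 2 lie within the scatter of each other, while compound 1 sits at a far higher number, well beyond the scatter. Compound 4 `O=C(O)Cc1sc(C(c2ccc(F)cc2)c2ccc(F)cc2)nc1-c1ccnc(N2CCCC2)c1` differs from compound 3 at one place: 2-(pyrrolidin-1-yl)pyridin-4-yl in place of furan-2-yl on an aromatic carbon. Among the measured compounds shown here, no measured pair here shows a like change, so the size of this step is uncertain. The step from compound 3 to compound 4 in this assay is expected to be small, a 1.7-fold higher number from compound 3 to compound 4 (0.22 log units; within the scatter), as likely up as down. Compound 4 is estimated at 30 nM, with a range from 5 nM to 200 nM.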

Compound 4, half-maximal inhibitory concentration: 230 nM
Estimate against measurement, compound 4: 7.7-fold (0.88 log units) below, outside the stated range (above it).
By their numbers in this assay, from the lowest: compounds 2 and 3 (each within the scatter of the next); then compound 4; then compound 1.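

In this assay, putting 2-(pyrrolidin-1-yl)pyridin-4-yl in place of furan-2-yl gives a 13-fold higher number from compound 3 to compound 4 (1.11 log units; beyond the scatter), so this aromatic carbon next to the ring nitrogen does not accept every aromatic group equally. Among the compounds shown here, this is the first change at a single place in this set, and the earlier compounds could not show how large such a step can be. Nothing available here explains the weaker binding. Still open, on these data alone, is whether the step comes from the pyridine ring or from the pyrrolidine on it. A plain pyridin-4-yl group, or a dimethylamino group in place of the pyrrolidine, would help separate the two.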